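Amidine in Place of Guanidine on the Longer Core

A few compounds are considered here, and "the series" means these few. Any claim that something is new, unique, unknown or untested is made for them only; others in the source may bear on it.

Three compounds have been measured in a functional assay for inhibition, with Cavia porcellus as the target; a lower number here means a stronger inhibitor, a higher number a weaker inhibitor:

compound 1, `N=C(N)Nc1ccc(C(=O)NCC[C@H]2C(=O)N(CC(=O)O)CCN2C(=O)CNC(=O)c2ccc(NC(=N)N)cc2)cc1`, 97 nM
compound 2, `N=C(N)Nc1ccc(C(=O)NCCC[C@H]2C(=O)N(CC(=O)O)CCN2C(=O)CNC(=O)c2ccc(NC(=N)N)cc2)cc1`, 51 nM
compound 3, `N=C(N)Nc1ccc(C(=O)NCC[C@H]2C(=O)N(CC(=O)O)CCN2C(=O)CNC(=O)c2ccc(C(=N)N)cc2)cc1`, 37 nM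

Compound 1 and compound 3 share a core and differ in one place, (a group of 3 heavy atoms (1 carbon, 2 nitrogen; no ring) in place of a group of 4 heavy atoms (1 carbon, 3 nitrogen; no ring), on an aromatic carbon). That change brought a 2.6-fold lower number from compound 1 to compound 3 (0.42 log units; beyond the scatter). Compound 2 has a different core from compound 1; the difference between the two cores is not broken down here. Compound 2 and compound 3 lie within the scatter of each other in this assay, as do compound 2 and compound 1.

Compound 4, `N=C(N)Nc1ccc(C(=O)NCCC[C@H]2C(=O)N(CC(=O)O)CCN2C(=O)CNC(=O)c2ccc(C(=N)N)cc2)cc1`, has not yet been measured. It differs from compound 2 by a group of 3 heavy atoms (1 carbon, 2 nitrogen; no ring) in place of a group of 4 heavy atoms (1 carbon, 3 nitrogen; no ring), on an aromatic carbon, the same change that turned compound 1 into compound 3, at the same place. Because compound 1 to compound 3 gave a 2.6-fold lower number from compound 1 to compound 3 (0.42 log units; beyond the scatter), the step from compound 2 to compound 4 in this assay is expected to be of like size, about a 2.6-fold lower number from compound 2 to compound 4 (0.41 log units; beyond the scatter). Compound 4 is therefore estimated at 20 nM, expected to fall between 8 nM and 50 nM.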

Compound 4, half-maximal inhibitory concentration: 19 nM
The estimate for compound 4 lay 1.1-fold (0.02 log units) above the measured number; low and high end bracket the measured number.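

In this assay, putting the group of 3 heavy atoms in place of the group of 4 heavy atoms, on an aromatic carbon of the same ring, brought a 2.7-fold lower number from compound 2 to compound 4 (0.43 log units; beyond the scatter), and the step kept its size on the second core: the same change on two cores in this assay, a 2.6-fold lower number (0.42 log units; beyond the scatter) from compound 1 to compound 3 and a 2.7-fold lower number (0.43 log units; beyond the scatter) from compound 2 to compound 4, 1.0-fold (0.01 log units) apart, within the scatter of two such steps. The change can therefore be carried between the core of compound 1 and the core of compound 2 with no sign in these numbers that either core alters its size. Going by these compounds alone, this does not show that it would carry to other cores, since it rests on only two matched pairs in a single assay, and it gives no reason why the number falls.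

The compounds shown leave open what an amine or a nitrile in that same place would do to the number. They also leave open whether a longer chain on the core than that of compound 2 would keep the step at this size.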